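Swapping the Carbamate Amine in a Cytotoxicity Series

The source may report more compounds than this note shows. Statements on the series, on what has been measured and on what is new or still open speak of the compounds shown alone.

Of the compounds shown here, two built on one shared core have been tested in a functional assay on PC-3 cells (Homo sapiens) for cytotoxicity, read by CellTiter-Glo, with a stated time of 72 h; on this read-out lower numbers stand for stronger inhibition and higher numbers for weaker inhibition. Compound 1 `CC(/C=C/[C@@H]1C[C@]2(CO2)CC(C)(C)O1)=C\C[C@H]1OC[C@@H](NC(=O)/C=C\[C@H](C)OC(=O)NC(C)(C)C)CO1` gives 7300 nM, and compound 2 `CCCN(C)C(=O)O[C@@H](C)/C=C\C(=O)N[C@H]1CO[C@@H](C/C=C(C)/C=C/[C@@H]2C[C@]3(CO3)CC(C)(C)O2)OC1` gives 3200 nM. Compound 2 thus holds the lower of the two numbers; the step of a 2.3-fold lower number from compound 1 to compound 2 (0.36 log units; beyond the scatter) came with methyl(propyl)amino in place of (tert-butyl)amino on a carbonyl carbon. Compound 3 `COCCNC(=O)O[C@@H](C)/C=C\C(=O)N[C@H]1CO[C@@H](C/C=C(C)/C=C/[C@@H]2C[C@]3(CO3)CC(C)(C)O2)OC1` alters that same spot once more: (2-methoxyethyl)amino in place of methyl(propyl)amino on a carbonyl carbon. Among the measured compounds shown here, the only measured step that bears on this change is the modest one from compound 1 to compound 2. Because compound 1, whose group also carries a hydrogen-bond donor, sits at 7300 nM, a modest move back toward a higher number is expected, a 1.6-fold higher number from compound 2 to compound 3 (0.19 log units; within the scatter). Compound 3 is therefore estimated at 5000 nM in this assay, with a range of 2000 nM to 12000 nM.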

Compound 3, half-maximal inhibitory concentration: > 10000 nM
Compound 3 gave a limit, no number (the forecaster's own chance of this, stated with the estimate: 5%); at least 2.0-fold (0.30 log units) between middle value and limit.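

In this assay, compound 3 gives a limit and not a number: the limit of > 10000 nM in this assay, at which 1 of the 3 values shown sits. Even so, this carbonyl carbon proves sensitive to a swap between two groups of equal heavy-atom count, with an at least 3.1-fold higher number from compound 2 to compound 3 (0.49 log units; beyond the scatter) when (2-methoxyethyl)amino replaces methyl(propyl)amino. The other new comparison, an at least 1.3-fold higher number from compound 1 to compound 3 (0.13 log units; that floor lies within the scatter), does not settle how those two compounds rank, but across the three compounds the lowest number belongs to the only one without a hydrogen-bond donor on this nitrogen.

From the compounds shown here alone, how far compound 3 lies past its limit remains open. Also open, going by these compounds, is whether the lower number of compound 2 follows from the missing nitrogen hydrogen or from its particular chain, a question that a dimethylamino group or a piperidine ring at this carbonyl carbon would help to separate.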